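The source may hold more compounds than are shown below. What is called first, only, known or untested is meant among the compounds shown, and "the series" means these compounds.

Measured so far:
Compound 1, `CCC1=C(O)c2c(oc(-c3ccc(C)c(C)c3)cc2=O)C(CC)(CC)C1=O`: 0.71 uM
Compound 2, `CCC1=C(O)c2c(oc(-c3ccc(OC)c(Cl)c3)cc2=O)C(CC)(CC)C1=O`: 1.37 uM

Compound 2 gives the higher of the two numbers in a functional assay on KBVIN cells (Homo sapiens) for antiproliferative activity, read by sulforhodamine B assay, with a stated time of 3 days (a higher number here means that more compound is needed for the effect, a lower number that less compound is needed), but its distance to compound 1 is within the scatter, so the two cannot be ranked. Compound 3, `CCC1=C(O)c2c(oc(-c3cc(C)ccc3C)cc2=O)C(CC)(CC)C1=O`, is not yet measured; it differs from compound 2 in one place: 2,5-dimethylphenyl in place of 3-chloro-4-methoxyphenyl on an aromatic carbon. Going by the values given here, the one measured step, a 1.9-fold higher number from compound 1 to compound 2 (0.29 log units; within the scatter), swaps groups at this same position and stays within the scatter. Because that step, a 1.9-fold higher number from compound 1 to compound 2 (0.29 log units; within the scatter), was small, no shift beyond the scatter is expected for compound 3. Compound 3 is estimated at 1 uM, with a range from 0.4 uM to 2.5 uM, an expected step of a 1.4-fold lower number from compound 2 to compound 3 (0.14 log units; within the scatter).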

Compound 3, concentration for half-maximal effect: 3.41 uM
Compound 3: the middle estimate sits 3.4-fold (0.53 log units) below what was measured; the measured number lies above the stated range.
By their numbers in this assay, from the lowest: compounds 1 and 2 (each within the scatter of the next); then compound 3.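

In this assay this position now shows a 2.5-fold higher number from compound 2 to compound 3 (0.40 log units; beyond the scatter) and a 4.8-fold higher number from compound 1 to compound 3 (0.68 log units; beyond the scatter) beyond the scatter, so the group here can change the number. Going by these compounds alone, the second step is the more telling: 3,4-dimethylphenyl and 2,5-dimethylphenyl are both dimethylphenyl groups, and moving the methyl groups around the ring is the only change. Nothing at hand explains this shift. Still open, on these data alone, is whether the whole 2,5-dimethylphenyl group or just one of its methyl groups accounts for the higher number, and how a plain phenyl or a ring carrying an amine would compare.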